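The source may hold more compounds than are shown below. What is called first, only, known or untested is meant among the compounds shown, and "the series" means these compounds.

Three related compounds have been measured so far in a physicochemical assay for lipophilicity, read by HPLC, using the shake flask method; a lower number here means a more polar compound, a higher number a more lipophilic compound. Compound 1 `C/C(=N\C#N)N(Cc1ccccc1)Cc1ccc(Cl)nc1` gives 2.11, compound 2 `CCCCN(Cc1ccc(Cl)nc1)/C(C)=N/C#N` gives 2.13, and compound 3 `CN(Cc1ccc(Cl)nc1)/C(=N/C#N)c1ccccc1` gives 1.86. All three numbers lie within the usual scatter of one another, so compound 2 stands level with the other two.

The next compound, compound 4 `C=CCN(Cc1ccc(Cl)nc1)/C(C)=N/C#N`, has not yet been measured. It differs from compound 2 in one place: vinyl in place of propyl on a saturated chain carbon bound to an amine nitrogen. In words, this is vinyl in place of propyl on a saturated chain carbon bound to an amine nitrogen. The same difference, cut one bond further out, reads butyl to allyl.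

Within the data shown here, only one measured step bears on this, and it lies at the same place: a number 0.02 log units higher from compound 1 to compound 2 (within the scatter). That step stays within the scatter, even with propyl in place of phenyl, but it involves no double bond, so it is only a loose guide. The entering group is smaller than the one that leaves, so a modest fall is expected in this assay, probably just beyond the scatter. The estimated change is a number 0.53 log units lower from compound 2 to compound 4 (beyond the scatter). For compound 4 the expected value is 1.6, within an estimated range from 1.3 to 1.9.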

Compound 4, partition coefficient: 1.56
Compound 4: the middle estimate sits 0.04 log units above what was measured; the range from low to high includes it.
By their numbers in this assay, from the lowest: compounds 4, 3, 1 and 2 (each within the scatter of the next, the first and the last beyond it).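

Among these compounds, until now this place looked indifferent in this assay: the one step there (a number 0.02 log units higher from compound 1 to compound 2 (within the scatter)) stayed within the scatter, even with propyl in place of phenyl. Vinyl, with 2 heavy atoms and 1 double bond outside aromatic rings, now gives steps beyond the scatter against both propyl (a number 0.57 log units lower from compound 2 to compound 4 (beyond the scatter)) and phenyl (a number 0.55 log units lower from compound 1 to compound 4 (beyond the scatter)), so a change on a saturated chain carbon bound to an amine nitrogen can shift this read-out, though both steps are modest in size. No measurement shown here accounts for these steps, and the entering vinyl differs from propyl both in its heavy atom count and in its double bond.

An ethyl at this place, with the same count of heavy atoms as vinyl but no double bond, would help tell those two differences apart. As far as these compounds go, how a longer chain, or a chain carrying an amine or a carboxylic acid, would read at this place also remains open.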